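Ester to acid on the halogenated indole series

The compounds below may be only part of what the source reports. "The series", "measured", "known", "first", "only" and "open" are said of these compounds alone.

In a functional assay on HBL-100 cells (Homo sapiens) for inhibition, read by sulforhodamine B assay, with a stated time of 48 h (on this read-out higher numbers stand for weaker inhibition of growth and lower numbers for stronger inhibition of growth), compound 1 `COC(=O)[C@@]1(C)CCC=C2[C@@H]1CC[C@@H](C)[C@]2(C)Cc1c[nH]c2c(Cl)cccc12` gives 19000 nM and compound 2 `COC(=O)[C@@]1(C)CCC=C2[C@@H]1CC[C@@H](C)[C@]2(C)Cc1c(C)[nH]c2ccc(Cl)cc12` gives 15000 nM; these two values lie within the scatter of each other, so no order between them is claimed. For compound 3 `COC(=O)[C@@]1(C)CCC=C2[C@@H]1CC[C@@H](C)[C@]2(C)Cc1c(C)n(C(c2ccccc2)c2ccccc2)c2ccc(Cl)cc12` this assay reports only a limit, > 100000 nM. Compound 3 therefore stands at the limit of > 100000 nM in this assay, at which 1 of the 3 values shown sits, and no number is known for it. Compound 4 `Cc1c(C[C@]2(C)C3=CCC[C@](C)(C(=O)O)[C@H]3CC[C@H]2C)c2cc(Cl)ccc2n1C(c1ccccc1)c1ccccc1` differs from compound 3 by hydrogen in place of methyl on an oxygen next to a carbonyl group, in words hydrogen in place of methyl on an oxygen next to a carbonyl group. Among the measured compounds shown here, no measured pair shows this change, so the size of its step is not known from the data. Given that compound 3 already sits at the limit, the expectation is no step beyond the scatter in either direction, with a real chance that compound 4 is again reported only as a limit. Compound 4 is expected at 100000 nM, with a range from 30000 nM to 300000 nM. This estimate amounts to an expected step of a number no higher from compound 3 to compound 4 (the limit leaves the size open), nothing beyond the scatter.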

Compound 4, concentration for 50% growth inhibition: 13000 nM
Estimate against measurement, compound 4: 7.7-fold (0.89 log units) above; the measured number lies below the stated range.
By their numbers in this assay, from the lowest: compounds 4, 2 and 1 (each within the scatter of the next). At a limit, above all of these: compound 3.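

Methoxycarbonyl to carboxy gives, in this assay, an at least 7.6-fold lower number from compound 3 to compound 4 (0.88 log units; beyond the scatter). This is the only step that can be read among the compounds shown, and it shows that the read-out responds to hydrogen in place of methyl on an oxygen next to a carbonyl group, in the direction of stronger inhibition of growth. Only a lower bound on the step's size can be given, since the value for compound 3 is a limit and not a number: the limit of > 100000 nM in this assay, at which 1 of the 4 values shown sits.

Going by these compounds, whether the same change gives a step of similar size on compound 1 or compound 2, which both carry the methoxycarbonyl group, remains open. Also open, on these data alone, is how a primary amide or a hydroxymethyl group at this place would read against the carboxy group of compound 4.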